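The compounds below may be only part of what the source reports. "The series", "measured", "known", "first", "only" and "open" are said of these compounds alone.

Measured so far:
- compound 1, `Nc1scc(CN2CCN(c3ccc([N+](=O)[O-])cc3)CC2)c1C(=O)c1ccc(Cl)cc1`: -17%
- compound 2, `Nc1scc(CN2CCN(c3ccc(F)c(F)c3)CC2)c1C(=O)c1ccc(Cl)cc1`: -87%

Going by the values given here, in a functional assay on CHO cells with adenosine receptor A1 (Homo sapiens) as the target, read by cAMP accumulation and immunoassay, with a stated time of 6 min, tested at 10 uM (a higher number here means a weaker effect of the compound at the concentration tested, a lower number a stronger effect), compound 2 gives the lower of the two numbers; the only other measured compound, compound 1, gives -17% and sits clearly higher. Among the compounds with values here, the one measured step, a number 70 percentage points lower from compound 1 to compound 2 (beyond the scatter), is the change from 4-nitrophenyl to 3,4-difluorophenyl on the amine nitrogen in the ring.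

The next compound is compound 3, `Nc1scc(CN2CCN(c3cccc(F)c3F)CC2)c1C(=O)c1ccc(Cl)cc1`. It differs from compound 2 by 2,3-difluorophenyl in place of 3,4-difluorophenyl on an amine nitrogen in a ring. The two fluorines stay on the same phenyl ring and nothing else moves. Within the data shown here, the measured step from compound 1 to compound 2 exchanges the whole aryl group for a different one and so does not bear directly on a shift of the two fluorines within the same ring; no step informs that change. With nothing to set a direction, the expected step of a number 12 percentage points higher from compound 2 to compound 3 (beyond the scatter) is none beyond the scatter, with a wider range to allow for the unknown effect of the changed fluorine pattern.

Compound 3 is therefore estimated at -75% in this assay, within -100% to -35%.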

Compound 3, a percentage reported as activity, at one concentration (the size of the read-out at that concentration, not a potency): -79%
The estimate for compound 3 lay 4 percentage points above the measured number, within the range that was stated.
By their numbers in this assay, from the lowest: compounds 2 and 3 (each within the scatter of the next); then compound 1.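

In this assay the two fluorines can sit in either arrangement on this phenyl ring, on the amine nitrogen in the six-membered ring, without a readable change: the shift gives a number 8 percentage points higher from compound 2 to compound 3 (within the scatter) and so the 2,3-difluorophenyl and 3,4-difluorophenyl groups cannot be told apart at this position, something the earlier pair could not show. The exchange of 4-nitrophenyl for 2,3-difluorophenyl gives a number 62 percentage points lower from compound 1 to compound 3 (beyond the scatter) and so the large separation from compound 1 no longer rests on a single difluorophenyl group, though this holds only for these three compounds. Nothing available here speaks to the origin of these numbers.

The compounds shown leave open whether fluorine is needed at all on this ring, since the series holds no unsubstituted phenyl, and whether a methoxyphenyl or a trifluoromethylphenyl group would fall with the difluorophenyl compounds or with compound 1. On these data alone, it also remains open whether an aromatic ring containing nitrogen, such as pyridyl, or a benzyl group could take the place of the phenyl ring on this amine nitrogen.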